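Morpholine amide on the shared core: an estimate

The source may report more compounds than this note shows. Statements on the series, on what has been measured and on what is new or still open speak of the compounds shown alone.

Measured compounds:
compound 1, `Cc1cccc(-n2cnc3cc(C(=O)N4CC(C)CC(C)C4)ccc32)c1`, 271 nM
compound 2, `Cc1cccc(-n2cnc3cc(C(=O)NC4CCCC4)ccc32)c1`, 961 nM

Of the compounds shown here, two sharing one core have been tested in an assay on isolated protein for inhibition of 15-hydroxyprostaglandin dehydrogenase [NAD(+)] (Homo sapiens), read by fluorescence, with a stated time of 15 min; a higher number here means a weaker inhibitor, a lower number a stronger inhibitor. Compound 1 gives 271 nM. Among the compounds with values here, compound 2 gives 961 nM, the higher of the two numbers, so compound 2 is the weaker inhibitor here; the step of a 3.5-fold higher number from compound 1 to compound 2 (0.55 log units; beyond the scatter) is the only measured step and it exchanges a cyclic tertiary amide for a secondary amide with an open amide hydrogen.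

Compound 3, `Cc1cccc(-n2cnc3cc(C(=O)N4CCOCC4)ccc32)c1`, has not been measured. It differs from compound 2 by morpholin-4-yl in place of cyclopentylamino on a carbonyl carbon. This change runs in the opposite sense to the measured step: a ring-bound nitrogen without an amide hydrogen returns on the carbonyl carbon, though the ring now carries an oxygen as well, for which no comparison exists.

Because a 3.5-fold higher number from compound 1 to compound 2 (0.55 log units; beyond the scatter) was modest, a movement of similar size back toward the number of compound 1 is expected, with wide uncertainty. The expected step is a 2.1-fold lower number from compound 2 to compound 3 (0.33 log units; beyond the scatter). Compound 3 is estimated at 450 nM, within 150 nM to 1400 nM.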

Compound 3, half-maximal inhibitory concentration: 3040 nM
Estimate against measurement, compound 3: 6.8-fold (0.83 log units) below; measured number above the stated range.
By their numbers in this assay, from the lowest: compound 1; then compound 2; then compound 3.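

In this assay, morpholin-4-yl in place of cyclopentylamino on a carbonyl carbon gives a 3.2-fold higher number from compound 2 to compound 3 (0.50 log units; beyond the scatter), so a ring-bound nitrogen without an amide hydrogen does not by itself bring back a low number. Morpholin-4-yl in place of 3,5-dimethylpiperidin-1-yl gives an 11-fold higher number from compound 1 to compound 3 (1.05 log units; beyond the scatter), the largest step of the three, which places two amides lacking the amide hydrogen at the two ends of the order, with the secondary amide of compound 2 in the middle, so the presence or absence of that hydrogen alone does not sort these numbers. No measurement here gives a reason for this order.

Compound 1 and compound 3 differ both in the ring oxygen and in the two methyl groups, so the compounds shown cannot assign the gap to either feature; plain piperidin-1-yl, which has neither, would separate the two. From the compounds shown here alone, the role of the amide hydrogen also remains open, and a cyclopentyl(methyl)amino group, which keeps the cyclopentyl ring but replaces that hydrogen with a methyl group, would test it directly against compound 2.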